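Swapping bromo for methyl on a weak inhibitor

The source may hold more compounds than are shown below. What is called first, only, known or untested is meant among the compounds shown, and "the series" means these compounds.

Compound 1, `CCN(CC)CCCn1c(=O)c(=Cc2ccccc2O)s/c1=C1\C(=O)Nc2ccc(Br)cc21`: 19900 nM
Compound 2, `CN(C)CCn1c(=O)c(=Cc2ccc(F)c(F)c2)s/c1=C1\C(=O)Nc2ccc(F)cc21`: 9480 nM

Of the compounds shown here, two with the shared core have been measured in a functional assay on MDA-MB-231 cells (Homo sapiens) for inhibition, read by MTT assay, with a stated time of 72 h; a lower number here means a stronger inhibitor, a higher number a weaker inhibitor. Compound 1 gives 19900 nM in this assay, and compound 2 gives 9480 nM in this assay. Of the two numbers, compound 1 holds the higher one, and the gap to compound 2 lies beyond the scatter of repeated measurements, so compound 2 is the stronger of the pair. Compound 2 differs from compound 1 at several places at once, so the two values attribute the gap to no single change.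

Compound 3 `CCN(CC)CCCn1c(=O)c(=Cc2ccccc2O)s/c1=C1\C(=O)Nc2ccc(C)cc21` has not been measured in this assay. It differs from compound 1 in one place: methyl in place of bromo on an aromatic carbon. Within the data shown here, no measured pair shows the effect of this change on the shared core, so the expectation rests on the modest scale of the change. A step of no more than the usual scatter is expected, in either direction, with a slight lean toward a higher number. The step from compound 1 to compound 3 is estimated as a 1.1-fold higher number from compound 1 to compound 3 (0.04 log units; within the scatter). Compound 3 is expected to give about 22000 nM in this assay, within a range from 8000 nM to 60000 nM.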

Compound 3, half-maximal inhibitory concentration: 15900 nM
Estimate against measurement, compound 3: 1.4-fold (0.14 log units) above; the range from low to high includes it.
By their numbers in this assay, from the lowest: compounds 2, 3 and 1 (each within the scatter of the next, the first and the last beyond it).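

In this assay, among these compounds, the exchange of bromo for methyl gives the first step that can be read at a single place on the shared core: a 1.3-fold lower number from compound 1 to compound 3 (0.10 log units; within the scatter). At this aromatic carbon, meta to a fused ring and para to a fused ring, bromo and methyl therefore cannot be told apart in this read-out, and the value stays in the same range as that of compound 1. No measurement at hand bears on why the two groups read alike.

The compounds shown leave open whether a different kind of group on this carbon, such as an amine, a carboxylic acid or a methoxy group, would give a step beyond the scatter, as only bromo and methyl can be compared here. As far as these compounds go, whether the exchange of bromo for methyl gives a similar step when the rest of the molecule carries the other substituents of compound 2 also remains open.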